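This account rests on a few compounds, and the source may have more. Where it says the series, first, only, none or still open, it means among the compounds named here.

In a functional assay on HepG2 cells (Homo sapiens) for antiproliferative activity, read by CCK-8 assay, with a stated time of 72 h (a lower number here means a stronger inhibitor, a higher number a weaker inhibitor), compound 1 `O=C(/C=C/c1ccc(CN2CCc3ccccc32)cc1)NO` gives 14900 nM, the higher of the two numbers available. Compound 3 `CCCc1ccc(OCc2ccc(C(=O)Nc3ccccc3N)cc2)cc1` gives 4750 nM, a gap beyond the scatter. Compound 2 `Nc1cnccc1NC(=O)/C=C/c1ccc(COc2ccccc2)cc1` reports only a limit, > 32000 nM. Compound 4 `Nc1ccccc1NC(=O)/C=C/c1ccc(CN2CCc3ccccc32)cc1` keeps the core of compound 1 and has 2-aminophenyl in place of hydroxy on an amide-type nitrogen. Among the compounds with values here, no two measured compounds differ in one place, so the size of this step is poorly constrained. Compound 3 also carries 2-aminophenyl on an amide-type nitrogen and gives 4750 nM, so no step beyond the scatter is expected in this assay. The expected step is a 1.1-fold lower number from compound 1 to compound 4 (0.03 log units; within the scatter). Compound 4 is estimated at 14000 nM, with a range of 4500 nM to 32000 nM.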

Compound 4, half-maximal inhibitory concentration: > 32000 nM
Compound 4 was reported as a limit; the forecaster's own chance of this, stated with the estimate: 30%; middle value at least 2.2-fold (0.35 log units) away from the limit.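

Within the data shown here, this is the first one-place comparison: in this assay, 2-aminophenyl in place of hydroxy on an amide-type nitrogen of the core of compound 1 gives an at least 2.1-fold higher number from compound 1 to compound 4 (0.33 log units; beyond the scatter). At this position, hydroxy is therefore the better of the two groups, a difference beyond the scatter. The true size of the step stays unknown, as compound 4 is reported only as a limit: the limit of > 32000 nM in this assay, at which 2 of the 4 values shown sit.

Open, as far as these compounds go, is whether 2-hydroxyphenyl or plain phenyl on that nitrogen would match 2-aminophenyl. Also open, from the compounds shown here alone, is whether methoxy in place of hydroxy would keep the number of compound 1.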